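Cytotoxicity on PC-3 cells: benzoyl for methoxycarbonyl

This account rests on a few compounds, and the source may have more. Where it says the series, first, only, none or still open, it means among the compounds named here.

Measured compounds in an ADME assay on PC-3 cells (Homo sapiens) for cytotoxicity, read by WST assay, tested at 100 uM; a lower number here means less inhibition, a higher number more inhibition at the concentration tested (going by the name of the read-out):
- compound 1 `CC(C)(C)OC(=O)c1cccc(NC(=O)C2CCCN(C(=O)c3cc(C(F)(F)F)cc(C(F)(F)F)c3)C2)c1`: 0%
- compound 2 `COC(=O)c1cccc(C(=O)N2CCCC(C(=O)Nc3ccc(Cl)cc3)C2)c1`: 0%
- compound 3 `CCc1cccc(NC(=O)C2CCCN(C(=O)c3cc(C(F)(F)F)cc(C(F)(F)F)c3)C2)c1`: 0%

All three measured compounds share the piperidine-carboxanilide core carrying an aroyl group on the ring nitrogen, and none shows any measurable effect in this assay. Going by the values given here, the single step between compounds differing in one place, ethyl in place of tert-butoxycarbonyl on an aromatic carbon, gives no change at the digits printed from compound 1 to compound 3 (within the scatter). Among the compounds with values here, compound 2, which carries a methoxycarbonyl on the aroyl ring and a chloro on the anilide, stands level with compounds 1 and 3 at the digits reported; no step is known between compound 2 and either of them.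

Compound 4 `O=C(c1ccccc1)c1cccc(C(=O)N2CCCC(C(=O)Nc3ccc(Cl)cc3)C2)c1` differs from compound 2 by phenyl in place of methoxy on a carbonyl carbon. Within the data shown here, no measured step changes this position, so the only guide is that every change so far, including the step from compound 1 to compound 3, has left the read-out unchanged within the scatter. Compound 4 is therefore expected to stay close to compound 2, with an expected step of a number 2 percentage points higher from compound 2 to compound 4 (within the scatter). The estimate for compound 4 in this assay is 2%, within a range of -8% to 15%.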

Compound 4, a percentage reported as inhibition, at one concentration (the size of the read-out at that concentration, not a potency): 0%
Compound 4: the middle estimate sits 2 percentage points above what was measured; the range from low to high includes it.
By their numbers in this assay, from the lowest: compounds 1, 2, 3 and 4 (each within the scatter of the next).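

Going by these compounds alone, on a carbonyl carbon whose other neighbour is an aromatic carbon, phenyl in place of methoxy is the first change read at this position, and in this assay it gives no change at the digits printed from compound 2 to compound 4 (within the scatter) as the only step known for compound 2. The change from methoxycarbonyl to benzoyl brings in a six-membered aromatic ring of carbon only and removes the hydrogen-bond acceptor of the methoxy, yet compound 4 gives 0% with that ring in place, so the absence of a read-out in this series now extends to a second kind of change, on the aroyl side of the shared core. Nothing available explains this absence of a change.

With all four compounds printed at one level in this assay, the series shows no group at this position that raises the read-out, and so it gives no ranking of the groups tried there. Going by these compounds, whether a carboxylic acid or an amine on this carbonyl carbon, or a longer chain in place of the phenyl, would move the read-out remains open.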